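This account rests on a few compounds, and the source may have more. Where it says the series, first, only, none or still open, it means among the compounds named here.

Compound 2, `ClCc1ccccc1Cn1cnc2ncnc(Cl)c21`, was examined in a functional assay on EKVX cells (Homo sapiens) for cytotoxicity, read by sulforhodamine B assay, with a stated time of 48 h (on this read-out higher numbers stand for lower toxicity in this test and lower numbers for higher toxicity in this test), where compound 2 gives 45700 nM. Its only measured companion, compound 1, `ClCc1ccccc1Cn1cnc2c(Cl)ncnc21`, shares the same chlorobenzyl arm and a chloro group on the fused core; in this assay compound 1 gives 37200 nM. The two numbers lie within the scatter of each other, so compound 2 cannot be set apart from compound 1 on these data.

Compound 3, `ClCc1ccccc1Cn1cnc2nc(Cl)nc(Cl)c21`, is built from compound 2 by a single change: chloro in place of hydrogen on an aromatic carbon. Among the measured compounds shown here, no measured pair in this set traces the effect of such an addition, so there is no step to lean on. The expectation is therefore that the step of a 1.3-fold lower number from compound 2 to compound 3 (0.12 log units; within the scatter) stays within the scatter, with no direction favoured. On that basis compound 3 is estimated at 35000 nM in this assay, with a range from 12000 nM to 100000 nM.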

Compound 3, concentration lethal to 50% of the cells: 6020 nM
For compound 3 the middle estimate is 5.8-fold (0.76 log units) above the measured one; measured number outside the range, below it.
By their numbers in this assay, from the lowest: compound 3; then compounds 1 and 2 (each within the scatter of the next).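

In this assay, chloro in place of hydrogen on an aromatic carbon, between two ring nitrogen atoms, brings a 7.6-fold lower number from compound 2 to compound 3 (0.88 log units; beyond the scatter) and so higher toxicity in this test. This shows that the position is not silent: a single added chlorine moves the read-out beyond the scatter, something that compound 1 and compound 2, whose numbers lie within the scatter of each other, could not show. Nothing at hand gives a reason for this step.

As far as these compounds go, only hydrogen and chloro are seen at this position, so it remains open whether the step is particular to chloro or would also follow fluoro, a methoxy group or an amine on the same carbon. From the compounds shown here alone, whether the same addition would act alike on the core of compound 1 also remains open.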